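Swapping the Ring on an Amide Nitrogen

The source may report more compounds than this note shows. Statements on the series, on what has been measured and on what is new or still open speak of the compounds shown alone.

Of the compounds shown here, three built on one shared core have been tested in a functional assay on CHO cells for agonist activity at Free fatty acid receptor 2 (Homo sapiens), read by cAMP accumulation; a lower number here means a stronger inhibitor, a higher number a weaker inhibitor. Compound 1 `CC(C)C(C(N)=O)c1ccc(Cl)cc1` is the smallest of them, and in this assay compound 1 gives only a limit of > 100000 nM, which is not a number. Compound 2 `CC(C)[C@H](C(=O)Nc1cccnn1)c1ccc(Cl)cc1` carries a pyridazin-3-yl ring on the amide nitrogen, and in this assay compound 2 gives 2300 nM. Compound 3 `CC(C)[C@H](C(=O)Nc1nnc(C(F)(F)F)s1)c1ccc(Cl)cc1` carries a different five-membered ring bearing a trifluoromethyl group at the same place, and in this assay compound 3 gives 1900 nM. Among the numbered values compound 2 stands highest, but its gap to compound 3 lies within the scatter, so the two read as alike.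

Compound 4 `CC(C)[C@H](C(=O)Nc1cnns1)c1ccc(Cl)cc1` has not yet been measured. It differs from compound 2 in one place: 1,2,3-thiadiazol-5-yl in place of pyridazin-3-yl on an amide-type nitrogen. For the measured compounds named here, no measured pair shows this exact change. The nearest guidance is compound 3, whose five-membered ring on the same nitrogen gives 1900 nM, close to the value of compound 2. A step of little size, none beyond the scatter, is therefore expected, a 1.3-fold higher number from compound 2 to compound 4 (0.12 log units; within the scatter). The estimate for compound 4 is 3000 nM, expected to fall between 1000 nM and 10000 nM.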

Compound 4, half-maximal inhibitory concentration: 57000 nM
Compound 4: the middle estimate sits 19-fold (1.28 log units) below what was measured, and the stated range ends below it.
By their numbers in this assay, from the lowest: compounds 3 and 2 (each within the scatter of the next); then compound 4. At a limit, above all of these: compound 1.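

For the compounds shown here, the ring on the amide-type nitrogen matters far more than the earlier compounds suggested: in this assay, 1,2,3-thiadiazol-5-yl in place of pyridazin-3-yl gives a 25-fold higher number from compound 2 to compound 4 (1.39 log units; beyond the scatter). A five-membered ring at this place does not settle the outcome by itself, as compound 3, whose five-membered ring bears a trifluoromethyl group, gives 1900 nM, while compound 4, whose five-membered ring has no such group, gives 57000 nM. Compound 1, which has no ring on this nitrogen, gives only a limit, which is not a number: the limit of > 100000 nM in this assay, at which 1 of the 4 values shown sits.

The change from compound 2 to compound 4 alters ring size and the set of hetero atoms together, so the compounds shown cannot tell which of these accounts for the step. Also open, as far as these compounds go, is whether a plain phenyl ring on this nitrogen, or a 1,2,3-thiadiazol-5-yl ring carrying a methyl group or an amine, would give a number closer to that of compound 2 or to that of compound 4.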